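A few compounds are considered here, and "the series" means these few. Any claim that something is new, unique, unknown or untested is made for them only; others in the source may bear on it.

Among the measured compounds shown here, compound 1 `CN(Cc1ccccc1)Cc1ccc[nH]1` is the weaker of the two compounds measured so far. In an assay on mitochondria for inhibition of Amine oxidase [flavin-containing] A (Bos taurus), read by fluorescence (a lower number here means a stronger inhibitor, a higher number a weaker inhibitor), compound 1 gives 3500 nM, the higher of the two numbers, while compound 2 `CN(CCCc1ccccc1)C(=O)c1ccc[nH]1` gives 40 nM in this assay, a gap far beyond the usual scatter. Compound 3 `c1ccc(CNCc2ccc[nH]2)cc1` has not been measured yet; it differs from compound 1 by hydrogen in place of methyl on an amine nitrogen. No single-change comparison among the measured compounds shows how this change acts, so no shift beyond the scatter is expected, and the expected step is small: a 1.2-fold lower number from compound 1 to compound 3 (0.07 log units; within the scatter). Compound 3 is therefore expected to give about 3000 nM in this assay, between 1000 nM and 10000 nM.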

Compound 3, inhibition constant: 350 nM
Estimate against measurement, compound 3: 8.6-fold (0.93 log units) above; measured number below the stated range.
By their numbers in this assay, from the lowest: compound 2; then compound 3; then compound 1.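

Within this assay, hydrogen in place of methyl on the amine nitrogen gives a 10-fold lower number from compound 1 to compound 3 (1.00 log units; beyond the scatter) and so moves the number beyond the scatter. Among the compounds shown here, this is the first single-change comparison available, and it shows that even one carbon on this nitrogen has a clear effect on the inhibition constant. Nothing in the data explains this shift. On these data alone, whether an ethyl group or a longer chain on this nitrogen would raise the number further remains open. So does whether the same change would have a similar effect on a different core.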